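A few compounds are considered here, and "the series" means these few. Any claim that something is new, unique, unknown or untested is made for them only; others in the source may bear on it.

Compound 2 `Nc1scc(CN2CCN(c3ccncc3)CC2)c1C(=O)c1ccc(Cl)cc1` carries a pyridin-4-yl group on the ring nitrogen of its central non-aromatic ring, and in a functional assay on CHO cells with adenosine receptor A1 (Homo sapiens) as the target, read by cAMP accumulation and immunoassay, with a stated time of 6 min, tested at 0.01 uM (a higher number here means a weaker effect of the compound at the concentration tested, a lower number a stronger effect), compound 2 gives -4%. Its two measured neighbours show essentially the same picture: compound 1 `Nc1scc(CN2CCN(c3ccc(OC(F)(F)F)cc3)CC2)c1C(=O)c1ccc(Cl)cc1` gives 0% in this assay, and compound 3 `Nc1scc(CN2CCC(c3ccc(Cl)cc3)CC2)c1C(=O)c1ccc(Cl)cc1`, which carries a chlorophenyl group on a carbon of that ring instead of an aryl group on a nitrogen, gives 0%. None of the three numbers can be told apart from the others, since every gap between them lies within the scatter, so compound 2 stands level with compound 1 and compound 3 rather than apart from them.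

Compound 4 `Nc1scc(CN2CCN(c3cc(F)ccc3F)CC2)c1C(=O)c1ccc(Cl)cc1` differs from compound 2 in one place: 2,5-difluorophenyl in place of pyridin-4-yl on an amine nitrogen in a ring. Going by the values given here, the only measured step that bears on this kind of change is the exchange of the aryl group on the same ring nitrogen a number 4 percentage points lower from compound 1 to compound 2 (within the scatter), which produced nothing beyond the scatter. With every related compound sitting at the baseline, no movement in this assay is expected, and the step of a number 4 percentage points higher from compound 2 to compound 4 (within the scatter) is estimated to stay within the scatter. Compound 4 is therefore expected to give about 0% in this assay, with a likely range from -10% to 10%.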

Compound 4, a percentage reported as activity, at one concentration (the size of the read-out at that concentration, not a potency): 3.1%
Compound 4: middle estimate off by 3.1 percentage points, on the low side; measured number inside the range.
By their numbers in this assay, from the lowest: compounds 2, 1, 3 and 4 (each within the scatter of the next).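

On the amine nitrogen in a ring, 2,5-difluorophenyl in place of pyridin-4-yl comes with a number 7.1 percentage points higher from compound 2 to compound 4 (within the scatter), and in place of 4-(trifluoromethoxy)phenyl with a number 3.1 percentage points higher from compound 1 to compound 4 (within the scatter). This adds a third aryl group on that nitrogen, and a carbon-only ring with two fluorine atoms, whose group counts no hydrogen-bond acceptor, cannot be told apart in this assay from either the pyridin-4-yl group, which counts one, or the 4-(trifluoromethoxy)phenyl group, so across these three compounds neither that ring nitrogen nor the fluorine atoms separate the read-out at this single concentration. No independent measurement is available to explain this flat result.

The compounds shown leave open whether a group of another kind on this nitrogen, such as an acetyl group, a longer alkyl chain or a phenyl ring bearing a carboxylic acid, would move the number beyond the scatter. Since the read-out comes from one concentration and is not a potency, they also leave open whether these aryl groups would differ from one another at other concentrations.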